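Swapping a Carbamate Ester for a Difluoropropyl Amide

The source may report more compounds than this note shows. Statements on the series, on what has been measured and on what is new or still open speak of the compounds shown alone.

Measured so far in a functional assay on isolated protein for inhibition of Glucose-dependent insulinotropic receptor (Homo sapiens), read by HTRF and cAMP accumulation; on this read-out lower numbers stand for an effect already at smaller amounts and higher numbers for an effect only at larger amounts of compound:
Compound 1, `Cc1nc(S(C)(=O)=O)ccc1Oc1ncnc(OC2CCN(C(=O)OC(C)C)CC2)c1F`, gives 21 nM.
Compound 2, `Cc1nc(S(C)(=O)=O)ccc1Oc1ncnc(OC2CCN(C(=O)O[C@@H](C)C(F)(F)F)CC2)c1F`, gives 9.86 nM.
Compound 3, `Cc1nc(S(C)(=O)=O)ccc1Oc1ncnc(OC2CCN(C(=O)OC3(C(F)(F)F)CCC3)CC2)c1F`, gives 14.3 nM.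

Compound 2 stands with the lowest of the three numbers in this assay, though only its gap to compound 1 lies beyond the scatter: a 2.1-fold lower number from compound 1 to compound 2 (0.33 log units; beyond the scatter). Its gap to compound 3 is within the scatter: a 1.5-fold higher number from compound 2 to compound 3 (0.16 log units; within the scatter). Compound 4, `CCC(F)(F)C(=O)N1CCC(Oc2ncnc(Oc3ccc(S(C)(=O)=O)nc3C)c2F)CC1`, has not been measured yet. It differs from compound 2 in one place: 1,1-difluoropropyl in place of 1-(trifluoromethyl)ethoxy on a carbonyl carbon.

None of the three measured steps makes this kind of change; all three vary only the group on an oxygen next to a carbonyl group and keep that oxygen in place. Those steps were small: a 2.1-fold lower number from compound 1 to compound 2 (0.33 log units; beyond the scatter), a 1.5-fold lower number from compound 1 to compound 3 (0.17 log units; within the scatter) and a 1.5-fold higher number from compound 2 to compound 3 (0.16 log units; within the scatter). The change to compound 4 removes that oxygen altogether, so the measured steps give only weak guidance. A step of no more than modest size in this assay is expected, with a slight lean toward a higher number: a 1.6-fold higher number from compound 2 to compound 4 (0.21 log units; within the scatter). Compound 4 is therefore estimated at 16 nM, with a range from 6 nM to 45 nM.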

Compound 4, half-maximal effective concentration: 17.4 nM
The estimate for compound 4 lay 1.1-fold (0.04 log units) below the measured number; measured number inside the range.
By their numbers in this assay, from the lowest: compounds 2, 3, 4 and 1 (each within the scatter of the next, the first and the last beyond it).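

In this assay, the oxygen on the carbonyl carbon can be removed and 1,1-difluoropropyl put in place of the whole alkoxy group without leaving the scatter of any of the three earlier compounds (a 1.8-fold higher number from compound 2 to compound 4 (0.25 log units; within the scatter); a 1.2-fold higher number from compound 3 to compound 4 (0.09 log units; within the scatter); a 1.2-fold lower number from compound 1 to compound 4 (0.08 log units; within the scatter)). The earlier compounds shown here varied only the group on that oxygen, so they could not show that these four numbers stay this close once the oxygen and the defined stereocentre of compound 2 are gone. Nothing measured here accounts for this closeness.

Going by these compounds, what a plain propyl chain without fluorine or an amine on the same carbonyl carbon would give remains open. So does the effect of a longer fluorinated chain at this place.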